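The source may report more compounds than this note shows. Statements on the series, on what has been measured and on what is new or still open speak of the compounds shown alone.

Measured compounds in an ADME assay on the whole organism with Oryza sativa as the target, tested at 1 uM; a lower number here means a stronger effect, a higher number a weaker effect of the compound at the concentration tested:
compound 1 `CC(C)c1cccc(NC(=O)N[C@H](C)c2ccccc2)c1` gives 61%
compound 2 `CC(C)c1cccc(NC(=O)N[C@@H](C)c2ccccc2)c1` gives 84%
compound 3 `C[C@@H](NC(=O)Nc1ccccc1Br)c1ccccc1` gives 100%

Compound 2 stands second highest of the three numbers in this assay: compound 3 sits a number beyond the scatter above it, compound 1 a number beyond the scatter below it. For the measured compounds named here, the only measured step between compounds that differ in one place is a number 23 percentage points higher from compound 1 to compound 2 (beyond the scatter); it rests on the fact that compounds 1 and 2 differ only in the configuration as drawn and concerns configuration alone, so it says nothing about exchanging a substituent on the ring.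

Compound 4 `C[C@H](NC(=O)Nc1cccc(I)c1)c1ccccc1` is not yet measured. The change from compound 2 is iodo in place of isopropyl on an aromatic carbon. Going by the values given here, no measured step exchanges one ring substituent for another, so no counted step bears on this change directly. Among the compounds with values here, the nearest number to compound 2 is that of compound 3, which gives 100%, but no step to it is counted and only its value can be weighed. On that basis a small upward step is expected, a number 6 percentage points higher from compound 2 to compound 4 (within the scatter), estimated rather than derived from a matching pair. Compound 4 is therefore expected to give about 90% in this assay, with a range from 70% to 100%.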

Compound 4, a percentage reported as activity, at one concentration (the size of the read-out at that concentration, not a potency): 95%
Beside the measured number, compound 4's estimate is 5 percentage points below it, within the range that was stated.
By their numbers in this assay, from the lowest: compound 1; then compound 2; then compounds 4 and 3 (each within the scatter of the next).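

In this assay, the series now has its first read exchange of one ring substituent for another, at the position on an aromatic carbon, meta to a large group: a number 11 percentage points higher from compound 2 to compound 4 (beyond the scatter). For the compounds shown here, the earlier step, a number 23 percentage points higher from compound 1 to compound 2 (beyond the scatter), concerned configuration alone, so this is the first indication that the number also responds to the group at this position, here moving towards a weaker effect when isopropyl, with its three carbon atoms, gives way to the single iodine atom of iodo, although neither group carries a hydrogen-bond donor, a hydrogen-bond acceptor or a net charge. Nothing available gives a cause for this step, and the configuration fact concerns only the other pair of compounds.

On these data alone, one exchange fixes no trend at this position, and it remains open whether a group such as an amine, a carboxylic acid, a methoxy group or a longer alkyl chain would move the number up or down from that of compound 2. Also open, as far as these compounds go, is whether the configuration step read with isopropyl in place would recur with iodo in that position.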